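This account rests on a few compounds, and the source may have more. Where it says the series, first, only, none or still open, it means among the compounds named here.

Compound 1, `O=C(CSc1ccc(Br)cc1)N1N=C(c2cc3ccccc3oc2=O)C[C@@H]1c1ccc(C(F)(F)F)cc1`, gives 10800 nM in a functional assay on MGC-803 cells (Homo sapiens) for cytotoxicity, read by MTT assay, with a stated time of 48 h (on this read-out higher numbers stand for weaker inhibition and lower numbers for stronger inhibition), the second highest of the three numbers measured. Its nearest neighbour is compound 3, `O=C(CSCc1ccco1)N1N=C(c2cc3ccccc3oc2=O)C[C@@H]1c1ccc(C(F)(F)F)cc1`, at 15200 nM, and the step of a 1.4-fold higher number from compound 1 to compound 3 (0.15 log units; within the scatter) is within the scatter. Compound 2, `CCCCSCC(=O)N1N=C(c2cc3ccccc3oc2=O)C[C@@H]1c1ccc(C(F)(F)F)cc1`, gives 2350 nM, and the step of a 4.6-fold lower number from compound 1 to compound 2 (0.66 log units; beyond the scatter) is beyond the scatter, as is the step of a 6.5-fold higher number from compound 2 to compound 3 (0.81 log units; beyond the scatter).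

Compound 4, `O=C(CSc1ccc(Br)cc1)N1N=C(c2cc3ccccc3oc2=O)C[C@@H]1c1ccccc1`, differs from compound 1 in one place: hydrogen in place of trifluoromethyl on an aromatic carbon. All three measured steps change the group on the sulfur of the side chain, and none alters the 4-(trifluoromethyl)phenyl on the shared core. For the measured compounds named here, no measured step therefore bears on the change from compound 1 to compound 4, and the data give no ground for expecting a shift in either direction in this assay.

With the group on the sulfur held as in compound 1, the expectation for compound 4 is a step of a 1.0-fold higher number from compound 1 to compound 4 (0.01 log units; within the scatter), that is, no change beyond the scatter. Compound 4 is therefore estimated at 11000 nM, with a range from 4000 nM to 30000 nM to allow for the absence of any comparable measured step.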

Compound 4, half-maximal inhibitory concentration: 16800 nM
Compound 4: middle estimate off by 1.5-fold (0.18 log units), on the low side; the measured number falls inside the stated range.
By their numbers in this assay, from the lowest: compound 2; then compounds 1, 3 and 4 (each within the scatter of the next).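

For the compounds shown here, this is the first measured change on the aromatic ring of the shared core rather than on the group on the sulfur. In this assay, the exchange of trifluoromethyl for hydrogen on an aromatic carbon, para to a large group, gives a 1.6-fold higher number from compound 1 to compound 4 (0.19 log units; within the scatter), so with 4-bromophenyl on the sulfur, the 4-(trifluoromethyl)phenyl to phenyl exchange stays within the scatter and the four heavy atoms of the trifluoromethyl group make no measurable difference to the number. The changes on the sulfur had included steps beyond the scatter, whereas this single step at the new position does not, although one step in one setting cannot define the position as a whole; no measurement at hand accounts for this result.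

The compounds shown leave open whether the same exchange would also stay within the scatter with the butyl of compound 2 on the sulfur, the setting with the lowest number so far. They also leave open how this assay would respond at this place to a group such as an amine, a carboxylic acid or a methoxy group.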